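From a hydroxypropyl chain to an aminobutyl chain

A few compounds are considered here, and "the series" means these few. Any claim that something is new, unique, unknown or untested is made for them only; others in the source may bear on it.

Among the compounds with values here, in a functional assay on SW-620 cells (Homo sapiens) for inhibition (on this read-out lower numbers stand for stronger inhibition and higher numbers for weaker inhibition), compound 2 `O=C1C2=C(C(=O)c3ccccc31)C1(CS2)NC(=O)N(CCCO)C1=O` gives 119 nM, the lower of the two numbers so far, while compound 1 `O=C1C2=C(C(=O)c3ccccc31)C1(CS2)NC(=O)N(CCO)C1=O` gives 198 nM; the step of a 1.7-fold lower number from compound 1 to compound 2 (0.22 log units; within the scatter) adds one chain carbon. Compound 3 `NCCN1C(=O)NC2(CSC3=C2C(=O)c2ccccc2C3=O)C1=O` carries an amine on a shorter chain and gives 35 nM; 34 nM; 47 nM (3 entries) in repeated runs (the several entries of compound 3 in this assay, 35 nM; 34 nM; 47 nM (3 entries)). Compound 4 `NCCCCN1C(=O)NC2(CSC3=C2C(=O)c2ccccc2C3=O)C1=O` is not yet measured and differs from compound 2 by aminomethyl in place of hydroxy on a saturated chain carbon, three bonds along the chain from an amide-type nitrogen in a ring. Within the data shown here, no measured step swaps hydroxy for an amine at fixed chain length. A modest downward step is nevertheless expected, a 2.4-fold lower number from compound 2 to compound 4 (0.38 log units; beyond the scatter), because compound 3 with its amine gives 35 nM; 34 nM; 47 nM (3 entries) while the chain extension in a 1.7-fold lower number from compound 1 to compound 2 (0.22 log units; within the scatter) stayed within the scatter. Compound 4 is thus estimated at 50 nM, between 20 nM and 150 nM.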

Compound 4, half-maximal inhibitory concentration: 68 nM
Estimate against measurement, compound 4: 1.4-fold (0.13 log units) below, and the stated range covers the measured number.
By their numbers in this assay, from the lowest: compounds 4, 2 and 1 (each within the scatter of the next, the first and the last beyond it).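

Replacing 3-hydroxypropyl with 4-aminobutyl gives a 1.8-fold lower number from compound 2 to compound 4 (0.24 log units; within the scatter), so this change does not clearly separate the two compounds. Set against the shorter 2-hydroxyethyl chain, the same 4-aminobutyl chain gives a 2.9-fold lower number from compound 1 to compound 4 (0.46 log units; beyond the scatter), which shows a real difference across the wider change. An amine at the chain end therefore remains compatible with activity on a longer chain, alongside the shorter amine chain of compound 3: the several entries of compound 3 in this assay, 35 nM; 34 nM; 47 nM (3 entries)

From the compounds shown here alone, what a 3-aminopropyl chain would give remains open. So does the effect of a carboxylic acid at the chain end.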